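A few compounds are considered here, and "the series" means these few. Any claim that something is new, unique, unknown or untested is made for them only; others in the source may bear on it.

Within the data shown here, compound 3 `COc1ccccc1OC(C)(C)C1OCC(C/C=C\CCC(=O)O)C(c2cccnc2)O1` is one of three compounds measured in an assay for inhibition of Thromboxane-A synthase (Homo sapiens), using microsomes (a higher number here means a weaker inhibitor, a lower number a stronger inhibitor), and compound 3 gives 60 nM. Compound 1 `O=C(O)CC/C=C\CC1COC(c2ccc(Cl)cc2Cl)OC1c1cccnc1` gives 42 nM, and compound 2 `O=C(O)CC/C=C\CC1COC(c2cccc3ccccc23)OC1c1cccnc1` gives 40 nM. Compound 3 has the highest of the three numbers, but its gaps to compound 1 and to compound 2 both lie within the scatter, so none of the three can be called stronger or weaker than another. Among the measured compounds shown here, the single step among measured compounds, a 1.1-fold lower number from compound 1 to compound 2 (0.02 log units; within the scatter), swaps one aromatic group for another on a saturated ring carbon and leaves the number within the scatter. Compound 4 `CC(C)(Sc1ccccc1)C1OCC(C/C=C\CCC(=O)O)C(c2cccnc2)O1` differs from compound 3 by phenylsulfanyl in place of 2-methoxyphenoxy on a saturated chain carbon bound to two saturated chain carbons and a saturated ring carbon. This change sits on a saturated chain carbon rather than on the ring carbon of that measured step, so the step bears on it only loosely; what it does show is that exchanging an aromatic group in this part of the molecule left the number within the scatter. The step of no change at the digits printed from compound 3 to compound 4 (within the scatter) is therefore expected to be small, with no change beyond the scatter in either direction. Compound 4 is estimated at 60 nM, with a range from 25 nM to 150 nM.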

Compound 4, half-maximal inhibitory concentration: 40 nM
Estimate against measurement, compound 4: 1.5-fold (0.18 log units) above; the measured number falls inside the stated range.
By their numbers in this assay, from the lowest: compounds 2, 4, 1 and 3 (each within the scatter of the next).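

In this assay, the exchange on this saturated chain carbon now has a step of its own: a 1.5-fold lower number from compound 3 to compound 4 (0.18 log units; within the scatter), so 2-methoxyphenoxy and phenylsulfanyl cannot be told apart here. The two oxygens and the methoxy group that leave, and the single sulfur that enters, thus bring no change beyond the scatter. Compound 4 also stays level with the compounds carrying their aromatic group on the saturated ring carbon, with no change at the digits printed from compound 2 to compound 4 (within the scatter) and a 1.1-fold lower number from compound 1 to compound 4 (0.02 log units; within the scatter), so these larger exchanges do not separate the compounds either.

The compounds shown leave open whether a group with no aromatic ring at this place, such as an amine or a carboxylic acid, would hold the number, and whether the sulfur and the loss of the methoxy group would each do so alone. No available evidence offers an account of these values.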